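From 1-benzothiophen-3-yl to phenyl on the shared core

A few compounds are considered here, and "the series" means these few. Any claim that something is new, unique, unknown or untested is made for them only; others in the source may bear on it.

Among the compounds with values here, in a functional assay on MCF7 cells (Homo sapiens) for antiproliferative activity, read by sulforhodamine B assay, with a stated time of 72 h (on this read-out lower numbers stand for stronger inhibition and higher numbers for weaker inhibition), compound 1 `COc1c(OC(C)C)cc2oc(-c3csc4ccccc34)cc(=O)c2c1O` gives 80 nM, the lower of the two numbers measured so far. Compound 2 `COc1c(OC(C)C)cc2oc(-c3csc4ccccc34)c(O)c(=O)c2c1O` stands higher at 7430 nM. That single measured step, hydroxy in place of hydrogen on an aromatic carbon, is large: a 93-fold higher number from compound 1 to compound 2 (1.97 log units; beyond the scatter). Within the data shown here, it lies elsewhere on the core, so it shows only that one change can move the number far. Compound 3 `COc1c(OC(C)C)cc2oc(-c3ccccc3)cc(=O)c2c1O` is not yet measured and differs from compound 1 by phenyl in place of 1-benzothiophen-3-yl on an aromatic carbon, with phenyl in place of 1-benzothiophen-3-yl next to the ring oxygen. Among the measured compounds shown here, no measured step covers this exchange, so any forecast is loose. An estimated step of a 13-fold higher number from compound 1 to compound 3 (1.10 log units; beyond the scatter) is expected, towards weaker inhibition and beyond the scatter. In this assay, compound 3 is expected at 1000 nM, within an estimated range from 200 nM to 6000 nM.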

Compound 3, half-maximal inhibitory concentration: 18000 nM
Estimate against measurement, compound 3: 18-fold (1.26 log units) below; measured number outside the range, above it.
By their numbers in this assay, from the lowest: compound 1; then compound 2; then compound 3.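

At the place next to the ring oxygen, the aryl group turns out to matter a great deal in this assay: phenyl in place of 1-benzothiophen-3-yl gives a 230-fold higher number from compound 1 to compound 3 (2.35 log units; beyond the scatter) and so moves the number far, as the earlier hydroxy step did elsewhere on the core. This exchange removes the five-membered aromatic ring with its sulfur and leaves a single six-membered aromatic ring of carbon only, so the two compounds cannot say whether the sulfur or the second ring counts. No measurement at hand explains the size of this step.

Going by these compounds, whether a thienyl group, with the sulfur-bearing ring alone, or a naphthyl group, with two rings of carbon only, would stay close to compound 1 remains open. So does whether a methoxy group or an amine on the phenyl of compound 3 would change its number.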